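The source may report more compounds than this note shows. Statements on the series, on what has been measured and on what is new or still open speak of the compounds shown alone.

Compound 2 `Nc1cc(N)c2nc(-c3ccccc3)c(Oc3ccc(F)cc3)nc2c1` and compound 1 `COc1ccc(Sc2nc3cc(N)cc(N)c3nc2-c2ccccc2)cc1` share one core and differ only in the group on the aromatic carbon beside the phenyl group. In a functional assay on SK-MEL-2 cells (Homo sapiens) for inhibition, read by sulforhodamine B assay, with a stated time of 48 h (a higher number here means that more compound is tolerated, a lower number that less compound is tolerated), compound 1 gives < 100000 nM, which is a limit of the assay and not a number. In this assay compound 2 likewise gives < 100000 nM, again a limit rather than a number. The step from compound 1 to compound 2 is therefore a step that the two limits leave unreadable from compound 1 to compound 2, and the evidence is summed up in the limit of < 100000 nM in this assay, at which 2 of the 2 values shown sit. Compound 2 thus stands only at a limit, with no measured number to place it.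

Compound 3 `Nc1cc(N)c2nc(-c3ccccc3)c(Sc3ccc(F)cc3)nc2c1` differs from compound 2 in the change ((4-fluorophenyl)sulfanyl in place of 4-fluorophenoxy on an aromatic carbon). Going by the values given here, no measured step bears on this change: the one step available is unreadable, since both of its ends sit at the limit. The expected step from compound 2 to compound 3 is accordingly a step that the limit leaves unreadable from compound 2 to compound 3, nothing beyond the scatter. Compound 3 is expected to give about 30000 nM in this assay, within a range from 5000 nM to 100000 nM, and most likely again only a limit.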

Compound 3, concentration lethal to 50% of the cells: < 100000 nM
Compound 3 ended at the assay's limit; the forecaster's own chance of this, stated with the estimate: 70%; the middle value does not contradict the limit.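

In this assay, going by these compounds alone, compound 3, like compound 1 and compound 2, stands only at a limit of the assay, and no step among the three can be read: the limit of < 100000 nM in this assay, at which 3 of the 3 values shown sit. The compounds shown leave open whether (4-fluorophenyl)sulfanyl in place of 4-fluorophenoxy, or fluoro in place of methoxy, changes the result at all; none of the three carries a number.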